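The source may report more compounds than this note shows. Statements on the series, on what has been measured and on what is new or still open speak of the compounds shown alone.

Compound 2 `CCCS(=O)(=O)Nc1ccc(F)c(C(=O)c2n[nH]c3ncc(-c4ccccc4O)cc23)c1F` holds the lowest number of the three measured in an assay for binding affinity to dual specificity mitogen-activated protein kinase kinase 4 (Homo sapiens), read by KINOMEscan, tested at 100 nM; a higher number here means a weaker effect of the compound at the concentration tested, a lower number a stronger effect: compound 2 gives 9%. Compound 1 `CCCS(=O)(=O)Nc1ccc(F)c(C(=O)c2n[nH]c3ncc(-c4cccc(C)c4)cc23)c1F` stands close by, since compound 1 gives 15%, and the step of a number 6 percentage points lower from compound 1 to compound 2 (within the scatter) lies within the scatter. Compound 3 `CCCS(=O)(=O)Nc1ccc(F)c(C(=O)c2n[nH]c3ncc(-c4cc(Cl)cc(Cl)c4)cc23)c1F` lies far off, as compound 3 gives 73%, so that a number 64 percentage points higher from compound 2 to compound 3 (beyond the scatter) and a number 58 percentage points higher from compound 1 to compound 3 (beyond the scatter) are both large steps toward weaker binding.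

Compound 4 `CCCS(=O)(=O)Nc1ccc(F)c(C(=O)c2n[nH]c3ncc(-c4ccc(Cl)c(C(F)(F)F)c4)cc23)c1F` has not yet been measured. Its change from compound 2 is 4-chloro-3-(trifluoromethyl)phenyl in place of 2-hydroxyphenyl on an aromatic carbon. The measured steps that bear on this are those where 3,5-dichlorophenyl entered: a number 64 percentage points higher from compound 2 to compound 3 (beyond the scatter) and a number 58 percentage points higher from compound 1 to compound 3 (beyond the scatter). Among the compounds with values here, compound 4 carries a chlorine and a trifluoromethyl on its phenyl, and no step with exactly this group is known, so the dichloro case is the nearest guide. The chemist therefore expects a large step upward, a number 46 percentage points higher from compound 2 to compound 4 (beyond the scatter), though smaller than the dichloro step is possible. The estimate for compound 4 is 55%, with a range from 25% to 85%.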

Compound 4, a percentage reported as activity, at one concentration (the size of the read-out at that concentration, not a potency): 15%
Compound 4: the middle estimate sits 40 percentage points above what was measured; the measured number lies below the stated range.
By their numbers in this assay, from the lowest: compounds 2, 1 and 4 (each within the scatter of the next); then compound 3.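

The step of a number 6 percentage points higher from compound 2 to compound 4 (within the scatter) and the step of no change at the digits printed from compound 1 to compound 4 (within the scatter) show that in this assay this position can carry a larger phenyl group bearing chlorine and trifluoromethyl, without the hydroxyl of compound 2, and still stay within the scatter of both earlier compounds. Chlorine on this phenyl is therefore not enough to give a high number, as the large step of a number 58 percentage points lower from compound 3 to compound 4 (beyond the scatter) separates two chlorine-bearing groups and leaves compound 3 alone at the weak end of the four. Nothing measured here explains why these two groups part so widely.

On these data alone, it remains open whether the high number belongs to the 3,5-dichloro arrangement itself, which 3,5-bis(trifluoromethyl)phenyl or 3-chlorophenyl would help to test. As far as these compounds go, how an aminophenyl or a carboxylic acid on the phenyl would read at this position also stays unknown.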